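A few compounds are considered here, and "the series" means these few. Any claim that something is new, unique, unknown or untested is made for them only; others in the source may bear on it.

In a functional assay on DU-145 cells (Homo sapiens) for cytotoxicity (a lower number here means a stronger inhibitor of growth, a higher number a weaker inhibitor of growth), compound 1 `OCC#Cc1ccccc1C#Cc1ccccc1` gives 14900 nM; compound 2 `OCCCCC#Cc1ccccc1C#Cc1ccccc1` gives 5220 nM; compound 3 `OCCCCC#Cc1ccccc1C#Cc1ccccc1C(F)(F)F` gives 6100 nM.

Among these three, compound 2 gives the lowest number, though the step of a 1.2-fold higher number from compound 2 to compound 3 (0.07 log units; within the scatter) is within the scatter, whereas a 2.9-fold lower number from compound 1 to compound 2 (0.46 log units; beyond the scatter) is beyond it. Compound 4 `OCCCCC#Cc1ccccc1C#Cc1cccc(O)c1` differs from compound 2 by hydroxy in place of hydrogen on an aromatic carbon. Of the measured steps, only a 1.2-fold higher number from compound 2 to compound 3 (0.07 log units; within the scatter) concerns a substituent on the same ring, and it stayed within the scatter; a 2.9-fold lower number from compound 1 to compound 2 (0.46 log units; beyond the scatter) concerns the chain and bears little on this change. Within the data shown here, no measured step shows a hydroxy on an aromatic carbon. Compound 4 is therefore expected to show a step of a 1.0-fold lower number from compound 2 to compound 4 (0.02 log units; within the scatter), no larger than the scatter. The estimate for compound 4 is 5000 nM, in a range from 2000 nM to 13000 nM.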

Compound 4, concentration for 50% growth inhibition: 17400 nM
The estimate for compound 4 lay 3.5-fold (0.54 log units) below the measured number, and the stated range ends below it.
By their numbers in this assay, from the lowest: compounds 2 and 3 (each within the scatter of the next); then compounds 1 and 4 (each within the scatter of the next).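

In this assay the step of a 3.3-fold higher number from compound 2 to compound 4 (0.52 log units; beyond the scatter) is beyond the scatter, so phenyl to 3-hydroxyphenyl weakens growth inhibition, a change of the size seen earlier only for the chain. The aromatic ring therefore does not tolerate every substituent, although the trifluoromethyl step a 1.2-fold higher number from compound 2 to compound 3 (0.07 log units; within the scatter) stayed within the scatter. No measurement available here explains the loss. Going by these compounds, whether a methoxy or an amine in the same place would also raise the number remains open, as does whether hydroxy has the same effect on the shorter chain of compound 1.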